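A few compounds are considered here, and "the series" means these few. Any claim that something is new, unique, unknown or untested is made for them only; others in the source may bear on it.

Measured so far:
compound 1 `CCOC(=O)Nc1ccc([Se]C#N)cc1` — 37% in a physicochemical assay, with a stated time of 180 min, tested at 0.5 mg/mL; on this read-out lower numbers stand for less inhibition and higher numbers for more inhibition at the one concentration tested (going by the name of the read-out)
compound 2 `O=C(Nc1ccc([Se][Se]c2ccc(NC(=O)OCc3ccccc3)cc2)cc1)OCc1ccccc1` — 7.4%

Within the data shown here, compound 1 stands highest of the two numbers in this assay; compound 2 lies below it by more than the scatter, but the two differ in more than one place, so no single step is drawn between them. Compound 3 `CCCCCCOC(=O)Nc1ccc([Se]C#N)cc1` is not yet measured. It differs from compound 1 by butyl in place of hydrogen on a saturated chain carbon, two bonds along the chain from an oxygen next to a carbonyl group. Among the measured compounds shown here, no measured pair shows a change of this kind, so the size of the step in this assay cannot be read from the data; a modest step, in either direction and close to the scatter, is expected. Compound 3 is estimated at 35%, between 15% and 55%. The expected step is a number 2 percentage points lower from compound 1 to compound 3 (within the scatter).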

Compound 3, a percentage reported as inhibition, at one concentration (the size of the read-out at that concentration, not a potency): > 25%
Compound 3 gave a limit, no number; the forecaster's own chance of this, stated with the estimate: 2%; the middle value is on the limit's open side.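

In this assay compound 3 gives > 25%, which is a limit and not a number. The step from compound 1 to compound 3 therefore cannot be read. The compounds shown leave open whether butyl in place of hydrogen changes the inhibition at all.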